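The compounds below may be only part of what the source reports. "The series", "measured", "known", "first", "only" and "open" are said of these compounds alone.

Measured in a functional assay on HepG2 cells (Homo sapiens) for antiproliferative activity, read by MTT assay, with a stated time of 3 days; a higher number here means a weaker inhibitor, a lower number a stronger inhibitor:
- compound 1 `CCCCCCCCC#Cc1cn(C/C=C\CN2C(=O)c3ccccc3C2=O)c(=O)[nH]c1=O`: 39000 nM
- compound 2 `CCCCCCCCC#Cc1cn(C/C=C/CN2C(=O)c3ccccc3C2=O)c(=O)[nH]c1=O`: 43000 nM
- compound 3 `CCCCCc1ccc(C#Cc2cn(C/C=C/CN3C(=O)c4ccccc4C3=O)c(=O)[nH]c2=O)cc1`: 4300 nM

Compound 1 lies within the scatter of compound 2, as a 1.1-fold higher number from compound 1 to compound 2 (0.04 log units; within the scatter) shows, and the values of both sit well above that of compound 3. The next compound to be tested is compound 4 `CCCCC#Cc1cn(C/C=C\CN2C(=O)c3ccccc3C2=O)c(=O)[nH]c1=O`, which keeps the double bond of compound 1 as drawn but has a shortened chain: hydrogen in place of butyl on a saturated chain carbon, four bonds along the chain from a triple-bonded carbon. In words, hydrogen stands in place of butyl on a saturated chain carbon, four bonds along the chain from a triple-bonded carbon.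

Within the data shown here, no measured step shortens a chain, so the evidence is indirect. The first step rests on the fact that compounds 1 and 2 differ only in the configuration as drawn and says nothing about chain length. The second, a 10-fold lower number from compound 2 to compound 3 (1.00 log units; beyond the scatter), exchanges the group on the triple-bonded carbon, and it shows that the number in this assay can respond to a change at that end of the molecule. A step of similar or smaller size is therefore expected, more likely toward a higher number, though it may stay within the scatter. The step estimated here is a 1.8-fold higher number from compound 1 to compound 4 (0.25 log units; within the scatter). For compound 4 the estimated value is 70000 nM, with an expected range from 25000 nM to 200000 nM.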

Compound 4, half-maximal inhibitory concentration: 17000 nM
The estimate for compound 4 lay 4.1-fold (0.61 log units) above the measured number, outside the stated range (below it).
By their numbers in this assay, from the lowest: compound 3; then compound 4; then compounds 1 and 2 (each within the scatter of the next).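

In this assay the shortened chain gives a 2.3-fold lower number from compound 1 to compound 4 (0.36 log units; beyond the scatter) and so shows that the group on the triple-bonded carbon can be changed in length alone, with the number moving beyond the scatter toward a stronger inhibitor. The earlier step at this end of the molecule put 4-pentylphenyl in place of octyl and so changed the kind of group, whereas this one keeps a plain saturated chain and takes off butyl, showing that the full chain of compound 1 is not needed for the activity seen there. The compounds shown offer nothing that explains this shift.

From the compounds shown here alone, with one shortened chain on hand, it remains open whether the number would keep falling with a still shorter chain such as methyl, rise again with a chain longer than that of compound 1, such as dodecyl, or respond to an amine or a carboxylic acid carried on the chain. Going by these compounds, it is also open whether the drawn E double bond, which makes no difference beyond the scatter with the longer chain, would behave the same way with the shortened chain of compound 4.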